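The source may report more compounds than this note shows. Statements on the series, on what has been measured and on what is new or still open speak of the compounds shown alone.

In a functional assay on OVCAR-8 cells (Homo sapiens) for inhibition, read by sulforhodamine B assay, with a stated time of 48 h, tested at 0.1 uM (on this read-out lower numbers stand for a stronger effect and higher numbers for a weaker effect at the one concentration tested), compound 1 `O=C(Nc1cccc(-n2cc(-c3ccncc3)c(-c3cc(O)cc(Cl)c3)n2)c1)Nc1ccc(Cl)c(C(F)(F)F)c1` gives 100%. Compound 2 `COc1cc(Cl)cc(-c2nn(-c3cccc(NC(=O)Nc4ccc(Cl)c(C(F)(F)F)c4)c3)cc2-c2ccncc2)c1` gives 96%, and compound 3 `COc1cc(Cl)cc(-c2nn(-c3cccc(NC(=O)Nc4cc(C(F)(F)F)cc(C(F)(F)F)c4)c3)cc2-c2ccncc2)c1` gives 105%; all three numbers lie within the usual scatter of one another, so none of them can be set apart. Among the measured compounds shown here, the one measured step, a number 4 percentage points lower from compound 1 to compound 2 (within the scatter), shows that a methyl in place of hydrogen on an oxygen on an aromatic ring changed nothing beyond the scatter. Compound 4 `COc1cc(Cl)cc(-c2nn(-c3cccc(NC(=O)c4cccc(C(F)(F)F)c4)c3)cc2-c2ccncc2)c1` differs from compound 2 in another place: 3-(trifluoromethyl)phenyl in place of (4-chloro-3-(trifluoromethyl)phenyl)amino on a carbonyl carbon. For the measured compounds named here, no measured step touches this carbonyl carbon, so there is nothing to build on except that every measured compound sits near the same number. The step from compound 2 to compound 4 is therefore expected to be a number 4 percentage points higher from compound 2 to compound 4 (within the scatter), with nothing beyond the scatter. Compound 4 is estimated to give 100%, between 85% and 115%.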

Compound 4, a percentage reported as activity, at one concentration (the size of the read-out at that concentration, not a potency): 94%
The estimate for compound 4 lay 6 percentage points above the measured number; measured number inside the range.
By their numbers in this assay, from the lowest: compounds 4, 2, 1 and 3 (each within the scatter of the next, the first and the last beyond it).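

Compound 4's side of the carbonyl carbon carries 3-(trifluoromethyl)phenyl where compound 2 has (4-chloro-3-(trifluoromethyl)phenyl)amino, and in this assay this gives a number 2 percentage points lower from compound 2 to compound 4 (within the scatter). Among the compounds shown here, this is the first look at this position, and the swap drops a hydrogen-bond donor and a chlorine without moving the number beyond the scatter. Nothing available explains why the number holds. As far as these compounds go, it remains open whether a simple amine or a carboxylic acid on this carbonyl carbon would shift the number beyond the scatter, and how all these compounds behave at other concentrations.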